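From Chloro to Fluoro: Expecting Little Change in Cytotoxicity

The compounds below may be only part of what the source reports. "The series", "measured", "known", "first", "only" and "open" are said of these compounds alone.

Compound 2 `O=C1COc2ccc(-c3nn(-c4ccc(Cl)cc4)cc3-c3ccccc3)cc2N1` was measured in a functional assay on A549 cells (Homo sapiens) for cytotoxicity, read by colorimetric assay and MTT assay, with a stated time of 3 days, tested at 20 uM (a higher number here means a weaker effect of the compound at the concentration tested, a lower number a stronger effect), and gives 52.4%. Among the compounds with values here, that is the higher of the two numbers measured so far, though the gap to its only neighbour is within the scatter: compound 1 `COc1ccc(-n2cc(-c3ccccc3)c(-c3ccc4c(c3)NC(=O)CO4)n2)cc1` in this assay gives 42.6%, and the step of a number 9.8 percentage points higher from compound 1 to compound 2 (within the scatter) does not exceed the usual variation. Compound 3 `O=C1COc2ccc(-c3nn(-c4ccc(F)cc4)cc3-c3ccccc3)cc2N1` has not yet been measured in this assay. It differs from compound 2 in one place: fluoro in place of chloro on an aromatic carbon. Within the data shown here, the only measured step that bears on this part of the molecule is a number 9.8 percentage points higher from compound 1 to compound 2 (within the scatter), which put chloro in place of methoxy on the same aromatic carbon and produced nothing beyond the scatter. A further change on that carbon, with chloro leaving and fluoro entering, is therefore expected to give a step of a number 2.4 percentage points lower from compound 2 to compound 3 (within the scatter) that again stays within the scatter, in no particular direction. On that basis compound 3 is expected to give about 50% in this assay, with a range from 35% to 65%.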

Compound 3, a percentage reported as activity, at one concentration (the size of the read-out at that concentration, not a potency): 56.4%
Estimate against measurement, compound 3: 6.4 percentage points below; low and high end bracket the measured number.
By their numbers in this assay, from the lowest: compounds 1, 2 and 3 (each within the scatter of the next, the first and the last beyond it).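

In this assay, exchanging 4-chlorophenyl for 4-fluorophenyl gives a number 4 percentage points higher from compound 2 to compound 3 (within the scatter) and so does not separate the two halogens on this aromatic carbon. Within the data shown here, the position is nevertheless not wholly silent, since the comparison of methoxy with fluoro on the same carbon gives a number 13.8 percentage points higher from compound 1 to compound 3 (beyond the scatter) and is the first step here to pass the scatter, though only modestly; compound 1 therefore has the stronger effect at the concentration tested than compound 3, while compound 2 remains within the scatter of both, so chloro does not fall clearly on either side. Nothing shown gives a measured property or other evidence that would account for these numbers.

The compounds shown leave open how a bare hydrogen, an amine, a carboxylic acid or an ether with a longer chain than methoxy on this carbon would read, and so whether the modest separation of compound 1 from compound 3 extends beyond these three groups. Each number gives the size of the effect at the one concentration tested, so they also leave open whether the compounds would show a stronger or weaker effect relative to one another at any other concentration.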